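This account rests on a few compounds, and the source may have more. Where it says the series, first, only, none or still open, it means among the compounds named here.

Working notes on the series. Compound 1 `OCCCCNCc1nc2c(OCC3CCCCC3)cccc2[nH]1` carries a 4-hydroxybutyl group on the amine nitrogen of the shared core; in an assay on cells for inhibition of interleukin-5 receptor subunit alpha (Mus musculus), read by WST assay, with a stated time of 48 h, in the presence of a further agent that is not named here (on this read-out lower numbers stand for stronger inhibition and higher numbers for weaker inhibition), compound 1 gives 30000 nM. Compound 2 `CC(C)(CO)NCc1nc2c(OCC3CCCCC3)cccc2[nH]1` carries 1-(hydroxymethyl)-1-methylethyl on that nitrogen, and in this assay compound 2 gives 27500 nM. Among the measured compounds shown here, the single measured step, a 1.1-fold lower number from compound 1 to compound 2 (0.04 log units; within the scatter), changes nothing beyond the scatter. On the two numbers shown, compound 2 stands lowest, with compound 1 within the scatter of it, so no order between them is claimed.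

Compound 3 `c1ccc(CNCc2nc3c(OCC4CCCCC4)cccc3[nH]2)cc1` is the next entry; the change from compound 2 is benzyl in place of 1-(hydroxymethyl)-1-methylethyl on an amine nitrogen. For the measured compounds named here, no measured step exchanges a hydroxyl-bearing group for an aromatic one, so the step in hand bears on it only loosely, showing that varying the group on this nitrogen so far left the number unchanged. Compound 3 is therefore expected to give an estimated 25000 nM, with a range of 7000 nM to 90000 nM. The step this estimate implies is expected to be a 1.1-fold lower number from compound 2 to compound 3 (0.04 log units; within the scatter), within the scatter.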

Compound 3, half-maximal inhibitory concentration: > 30000 nM
Compound 3: only a limit was reported; the forecaster's own chance of this, stated with the estimate: 20%; middle value at least 1.2-fold (0.07 log units) from the limit.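

Among the compounds shown here, compound 3 is the first entry with an aromatic ring on this amine nitrogen and no hydroxyl, and in this assay compound 3 gives > 30000 nM, which is a limit and not a number. From the compounds shown here alone, the step, an at least 1.0-fold higher number from compound 2 to compound 3 (0.03 log units; that floor lies within the scatter), shows that benzyl in place of 1-(hydroxymethyl)-1-methylethyl brought no lower number, while the true size of the change stays unknown. The other step, a number no lower from compound 1 to compound 3 (the limit leaves the size open), cannot be read for size, and this comparison rests on one reading: the limit of > 30000 nM in this assay, at which 1 of the 3 values shown sits.

Going by these compounds, still open, given a 1.1-fold lower number from compound 1 to compound 2 (0.04 log units; within the scatter), is whether an amine or a carboxylic acid in place of the hydroxyl, or a longer chain, would give a number beyond that scatter. Also open, on these data alone, is how a substituted benzyl on this nitrogen would read.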